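The compounds below may be only part of what the source reports. "The series", "measured", "known", "first", "only" and "open" are said of these compounds alone.

Compound 1 `Cc1cccnc1-c1cnc(C(=O)CCCCCCc2ccccc2)o1`: 15 nM
Compound 2 `CNC(=O)c1cnc(C(=O)CCCCCCc2ccccc2)o1`: 7 nM

For the measured compounds named here, in an assay (Rattus norvegicus) for inhibition of Fatty-acid amide hydrolase 1 (Homo sapiens) (a higher number here means a weaker inhibitor, a lower number a stronger inhibitor), compound 2 gives 7 nM, the lowest of the two numbers so far. Going by the values given here, the only measured step, a 2.1-fold lower number from compound 1 to compound 2 (0.33 log units; beyond the scatter), is modest but beyond the scatter. Compound 3 `CN1CCN(C(=O)c2cnc(C(=O)CCCCCCc3ccccc3)o2)CC1` differs from compound 2 in one place: 4-methylpiperazin-1-yl in place of methylamino on a carbonyl carbon. Among the compounds with values here, that one measured step exchanged the entire group on the aromatic carbon rather than the amine part of the carbamoyl, so it bears only loosely on the present change, and no measured pair shows what altering the amine on that carbonyl carbon does. The expected step from compound 2 to compound 3 is therefore small, within or just beyond the scatter, with a slight lean toward a higher number, a 1.7-fold higher number from compound 2 to compound 3 (0.23 log units; within the scatter). Compound 3 is estimated at 12 nM, with a range from 3 nM to 50 nM.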

Compound 3, inhibition constant: 80 nM
The estimate for compound 3 lay 6.7-fold (0.82 log units) below the measured number; the whole stated range lies below it.
By their numbers in this assay, from the lowest: compound 2; then compound 1; then compound 3.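

The amine on this carbonyl carbon turns out to matter far more than the earlier exchange of the whole group on the aromatic carbon suggested: in this assay there is an 11-fold higher number from compound 2 to compound 3 (1.06 log units; beyond the scatter), a large step, whereas the earlier step was modest. The carbonyl alone does not hold the number low, since there is also a 5.3-fold higher number from compound 1 to compound 3 (0.73 log units; beyond the scatter), so the 3-methylpyridin-2-yl group lies between the two amides. Nothing at hand gives a reason for the rise.

The change adds a six-membered ring and removes the amide hydrogen at once, and the compounds shown do not separate these two differences. A dimethylamino group or a morpholine on the same carbonyl carbon would bear on that question, as would a longer chain on the amide nitrogen.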